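The source may report more compounds than this note shows. Statements on the series, on what has been measured and on what is new or still open speak of the compounds shown alone.

Measured so far in an assay on Sf9 cells for inhibition of mitogen-activated protein kinase kinase kinase 14 variant S549D (Homo sapiens), with a stated time of 30 min, in the presence of a further agent that is not named here; on this read-out lower numbers stand for stronger inhibition and higher numbers for weaker inhibition:
- compound 1 `CCc1ccc2ncn(-c3ccnc(N)n3)c2c1`: 79400 nM
- compound 2 `C=Cc1ccnc(C#Cc2ccc3ncn(-c4ccnc(N)n4)c3c2)c1`: 1580 nM

Among the two numbers known in this assay, compound 2 stands with the lower one at 1580 nM, while compound 1 gives 79400 nM, a gap well beyond the usual scatter of repeated measurements.

Compound 3 `C=Cc1ccnc(C#Cc2ccc3ncn(-c4ccnc(N)n4)c3c2)n1` has not yet been measured. It differs from compound 2 in one place: a group of 8 heavy atoms (6 carbon, 2 nitrogen; one six-membered aromatic ring with 2 hetero atoms) in place of a group of 8 heavy atoms (7 carbon, 1 nitrogen; one six-membered aromatic ring with 1 hetero atom), on a triple-bonded carbon. Among the measured compounds shown here, no pair of measured compounds shows this kind of exchange, so there is no directly comparable step to lean on. The step from compound 2 to compound 3 in this assay is expected to be small, in either direction, and likely within the scatter.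

For compound 3 the estimated value in this assay is 1600 nM, with a range from 500 nM to 5000 nM, meaning an expected step of a 1.0-fold higher number from compound 2 to compound 3 (0.01 log units; within the scatter).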

Compound 3, half-maximal inhibitory concentration: 1580 nM
Compound 3: the middle estimate sits 1.0-fold (0.01 log units) above what was measured; measured number inside the range.
By their numbers in this assay, from the lowest: compounds 2 and 3 (each within the scatter of the next); then compound 1.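

In this assay, putting one six-membered aromatic ring with 2 hetero atoms in place of one with 1 hetero atom, on the triple-bonded carbon, gives no change at the digits printed from compound 2 to compound 3 (within the scatter) in this exchange. Among the compounds shown here, this is the first pair here that differs in one place, so it gives the first direct reading at this position: the added ring nitrogen and added hydrogen-bond acceptor leave the inhibition number within the scatter. Nothing measured here explains the result.

As far as these compounds go, only these two rings can be compared on the triple-bonded carbon, so it remains open whether an amine or a carboxylic acid on that ring would also leave the number within the scatter. From the compounds shown here alone, both compounds also carry the same double bond outside the aromatic ring, so the effect of replacing it with a longer chain remains unknown.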